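The source may report more compounds than this note shows. Statements on the series, on what has been measured and on what is new or still open speak of the compounds shown alone.

Measured so far:
- compound 1, `Cc1ccc(-n2cc(CNC(=O)c3cccc4c3cnn4C(C)C)nn2)cc1C`: in a functional assay on MCF7 cells (Homo sapiens) for inhibition, read by MTT assay, with a stated time of 72 h (a lower number here means a stronger inhibitor, a higher number a weaker inhibitor), compound 1 gives > 40000 nM, which is a limit of the assay and not a number.
- compound 2, `CC(C)n1ncc2c(C(=O)NCc3cn(-c4cccc(Br)c4)nn3)cccc21`: compound 2 gives > 40000 nM, again a limit of the assay.
- compound 3, `Cc1ccccc1-n1cc(CNC(=O)c2cccc3c2cnn3C(C)C)nn1`: compound 3 gives > 40000 nM, also a limit of the assay.

Compound 3 therefore stands nowhere distinct: its value, like that of the other two, sits at the limit of > 40000 nM in this assay, at which 3 of the 3 values shown sit. Between these three compounds only the group on the aromatic nitrogen changes, yet none of the steps can be read, neither a step that the two limits leave unreadable from compound 1 to compound 2, nor a step that the two limits leave unreadable from compound 1 to compound 3, nor a step that the two limits leave unreadable from compound 2 to compound 3.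

Compound 4, `CCc1ccc(-n2cc(CNC(=O)c3cccc4c3cnn4C(C)C)nn2)cc1`, is the next step on the same nitrogen: 4-ethylphenyl in place of 2-methylphenyl on an aromatic nitrogen. The three measured steps bear on it only in that every change of this group so far has left the value at the limit. Nothing in them points to a step in either direction, so compound 4 is expected to stay at the same limit, an expected step of a number no higher from compound 3 to compound 4 (the limit leaves the size open). The estimate for compound 4 is 40000 nM, with a range from 15000 nM to 100000 nM.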

Compound 4, half-maximal inhibitory concentration: > 40000 nM
Compound 4: a limit, no number; the forecaster's own chance of this, stated with the estimate: 85%; the middle value lies on the limit itself.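

For the compounds shown here, the result for compound 4 is a limit of the assay and not a number, as are those of compound 1, compound 2 and compound 3, so no step to compound 4 can be read: the limit of > 40000 nM in this assay, at which 4 of the 4 values shown sit. The compounds shown leave open whether changing the group on the aromatic nitrogen alters the value at all.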